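The source may report more compounds than this note shows. Statements on the series, on what has been measured and on what is new or still open speak of the compounds shown alone.

Working notes on the series, all read in a functional assay on MCF7 cells (Homo sapiens) for cytotoxicity, read by MTT assay; a higher number here means a weaker inhibitor, a lower number a stronger inhibitor. Compound 1 (`COc1ccc([C@@H]2C[C@@H]2c2cc(OC)c(OC)c(OC)c2)cc1O`) gives 102 nM, and compound 2 (`COCOc1cc(/C=C\c2cc(OC)c(OC)c(OC)c2)ccc1OC`) gives 269 nM. Compound 3 (`COCOc1cc(C2CC2c2cc(OC)c(OC)c(OC)c2)ccc1OC`) gives 14000 nM. That is the highest number of the three, which makes compound 3 the weakest inhibitor so far, and its gaps to both compound 2 and compound 1 lie beyond the scatter of repeated measurements.

Among the measured compounds shown here, compound 4 (`COc1ccc(C2CC2c2cc(OC)c(OC)c(OC)c2)cc1NC(=O)OC(C)(C)C`) has no measurement yet. Relative to compound 3, the change is (tert-butoxycarbonyl)amino in place of methoxymethoxy on an aromatic carbon, ortho to a methoxy group.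

For the measured compounds named here, no measured pair isolates a single change, so the data offer no direct guide to this replacement. Going by the values given here, the entering group also has no measured precedent here. The working anchor is therefore compound 3 at 14000 nM, and no step beyond the scatter is expected in either direction. The estimated change is a 1.4-fold lower number from compound 3 to compound 4 (0.15 log units; within the scatter), which stays within the scatter, although the uncertainty around it is wide. For compound 4 the expected value is 10000 nM, with an estimated range from 2000 nM to 40000 nM.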

Compound 4, half-maximal inhibitory concentration: 11800 nM
Compound 4: the middle estimate sits 1.2-fold (0.07 log units) below what was measured; low and high end bracket the measured number.
By their numbers in this assay, from the lowest: compound 1; then compound 2; then compounds 4 and 3 (each within the scatter of the next).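

In this assay, among the compounds shown here, a 1.2-fold lower number from compound 3 to compound 4 (0.07 log units; within the scatter) is the first single-place change measured, and it shows that on this aromatic carbon, ortho to a methoxy group, the assay does not separate methoxymethoxy from (tert-butoxycarbonyl)amino. The two groups are far from identical: the entering group has 8 heavy atoms against 4, and it has 1 hydrogen-bond donor where the leaving group has 0, yet the two compounds read alike within the scatter. Nothing measured here speaks to why compound 3 and compound 4 read alike.

Open, on these data alone, is whether a free amine or a small acetamide on this carbon would read differently from compound 4, since the two groups tested so far are both large protected substituents and neither shows what a smaller group would do on the core of compound 4. Also open, as far as these compounds go, is whether the same exchange would give a comparably small step on the core of compound 2, where the two aromatic rings are joined by a double bond in place of the three-membered ring.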